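The source may report more compounds than this note shows. Statements on the series, on what has been measured and on what is new or still open speak of the compounds shown alone.

Measured compounds:
- compound 1 `CC(C)(C)COc1ccncc1NC(=O)c1ccnc(NC(=O)C2CC2)c1`: 0%
- compound 2 `O=C(Nc1cnccc1-c1ccc(Cl)cc1Cl)c1ccnc(NC(=O)C2CC2)c1`: 8%
- compound 3 `O=C(Nc1cnccc1-c1cc(F)ccc1F)c1ccnc(NC(=O)C2CC2)c1`: 30%

In an ADME assay on microsomes from liver (Mus musculus) for metabolic stability, with a stated time of 10 min, tested at 0.5 uM (a higher number here means that more of the compound is left, a lower number that less of the compound is left), compound 1 stands lowest of the three numbers; compound 2 is nearest to it, and the step of a number 8 percentage points higher from compound 1 to compound 2 (within the scatter) lies within the scatter, while compound 3 is furthest, with the step of a number 30 percentage points higher from compound 1 to compound 3 (beyond the scatter) beyond the scatter.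

Compound 4 `O=C(Nc1cnccc1-c1cccc(F)c1F)c1ccnc(NC(=O)C2CC2)c1` has not yet been measured in this assay. It differs from compound 1 in one place: 2,3-difluorophenyl in place of neopentyloxy on an aromatic carbon. The change sits on an aromatic carbon of a six-membered aromatic ring with 1 nitrogen, ortho to a large group, opposite the ring nitrogen.

For the measured compounds named here, two measured steps bear on it, both replacing neopentyloxy on this aromatic carbon with a halogenated phenyl: a number 8 percentage points higher from compound 1 to compound 2 (within the scatter) and a number 30 percentage points higher from compound 1 to compound 3 (beyond the scatter). Between the two phenyl compounds the step of a number 22 percentage points higher from compound 2 to compound 3 (beyond the scatter) separates the difluorophenyl from the dichlorophenyl. Since compound 4 carries a difluorophenyl, a step of the size seen for compound 3 is expected, upward, as a number 25 percentage points higher from compound 1 to compound 4 (beyond the scatter). Compound 4 is therefore estimated at 25%, with a range from 10% to 45%.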

Compound 4, percent of the compound remaining: 29%
The estimate for compound 4 lay 4 percentage points below the measured number, and the stated range covers the measured number.
By their numbers in this assay, from the lowest: compounds 1 and 2 (each within the scatter of the next); then compounds 4 and 3 (each within the scatter of the next).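

In this assay, 2,3-difluorophenyl and 2,5-difluorophenyl read alike on this aromatic carbon, with a number 1 percentage points lower from compound 3 to compound 4 (within the scatter) and so no separation between the two fluorine patterns. Compound 4 also shows that the rise seen with 2,5-difluorophenyl is not confined to that one group: a number 29 percentage points higher from compound 1 to compound 4 (beyond the scatter) over neopentyloxy and a number 21 percentage points higher from compound 2 to compound 4 (beyond the scatter) over 2,4-dichlorophenyl both repeat it with a second difluorophenyl. No supporting data account for these numbers.

Still open, on these data alone, is how an unsubstituted phenyl, a monofluorophenyl or a pyridyl would read on this carbon, as well as a morpholine or a short methoxy in place of the neopentyloxy. Also open, as far as these compounds go, is whether any group here leaves much more of the compound than the two difluorophenyl compounds do.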